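The compounds below may be only part of what the source reports. "The series", "measured", "known", "first", "only" and "open" are said of these compounds alone.

Compound 1 `COc1ccc(-c2cn3ccnc3c(-c3ccc4ncn(C5CCCCC5)c4c3)n2)cc1`: 61.5%
Compound 2 `Fc1ccc(-c2cn3ccnc3c(-c3ccc4ncn(C5CCCCC5)c4c3)n2)cc1`: 37.8%

In a functional assay on UO-31 cells (Homo sapiens) for inhibition, read by sulforhodamine B assay, with a stated time of 48 h, tested at 10 uM (on this read-out lower numbers stand for less inhibition and higher numbers for more inhibition at the one concentration tested (going by the name of the read-out)), compound 2 stands lowest of the two measured compounds, below compound 1. For the measured compounds named here, the only measured step, a number 23.7 percentage points lower from compound 1 to compound 2 (beyond the scatter), swaps one group on the same aromatic carbon that compound 3 `CC(=O)c1ccc(-c2cn3ccnc3c(-c3ccc4ncn(C5CCCCC5)c4c3)n2)cc1` alters again, by acetyl in place of fluoro on an aromatic carbon. Going by the values given here, that step bears on the new one only loosely, since no measured compound carries an acetyl group. Compound 3 is therefore expected to land between the two measured values, a step of a number 12.2 percentage points higher from compound 2 to compound 3 (beyond the scatter) upward. The estimate for compound 3 is 50%, from 25% to 75%.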

Compound 3, a percentage reported as inhibition, at one concentration (the size of the read-out at that concentration, not a potency): 23.1%
For compound 3 the middle estimate is 26.9 percentage points above the measured one; the whole stated range lies above it.
By their numbers in this assay, from the lowest: compound 3; then compound 2; then compound 1.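

In this assay the 4-fluorophenyl to 4-acetylphenyl change gives a number 14.7 percentage points lower from compound 2 to compound 3 (beyond the scatter), and the methoxy to acetyl change gives a number 38.4 percentage points lower from compound 1 to compound 3 (beyond the scatter). The aromatic carbon para to a large group thus spans a wider range than the first swap showed, and acetyl, the larger of the groups here, does not fall between methoxy and fluoro. Nothing available explains this order.

On these data alone, whether an amine or a carboxylic acid at this carbon would read above compound 1 or below compound 3 remains open. So does whether this order holds on a different core.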